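The source may report more compounds than this note shows. Statements on the series, on what has been measured and on what is new or still open speak of the compounds shown alone.

Compound 1, `Cc1cc(NC(=O)c2cc([N+](=O)[O-])ccc2Cl)cc(-c2nc3ccccc3o2)c1O`: in an ADME assay on HEK293 cells (Homo sapiens) for cytotoxicity, with a stated time of 72 h (a higher number here means that more compound is needed for the effect, a lower number that less compound is needed), compound 1 gives > 25000 nM, which is a limit of the assay and not a number.
Compound 2, `Cc1cc(NC(=O)c2cc([N+](=O)[O-])ccc2Cl)cc(-c2nc3ccccc3s2)c1O`: in this assay compound 2 gives > 25000 nM, again only a limit.
Compound 3, `Cc1ccc(-c2nc3ccccc3s2)cc1NC(=O)c1cc([N+](=O)[O-])ccc1Cl`: in this assay compound 3 gives > 14000 nM, also a limit.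

None of the three measured compounds showed a measurable effect within the tested range. For the measured compounds named here, the only single-point change among them is 1,3-benzoxazol-2-yl in place of 1,3-benzothiazol-2-yl on an aromatic carbon, and its size, a step that the two limits leave unreadable from compound 2 to compound 1, stays hidden because compound 2 and compound 1 both sit at the limit of > 25000 nM in this assay, at which 2 of the 3 values shown sit. The difference between the cores of compound 2 and compound 3 is not broken down here.

Compound 4, `Cc1ccc(-c2nc3ccccc3o2)cc1NC(=O)c1cc([N+](=O)[O-])ccc1Cl`, has not yet been measured. It differs from compound 3 by 1,3-benzoxazol-2-yl in place of 1,3-benzothiazol-2-yl on an aromatic carbon. Going by the values given here, this is the same kind of change as the one from compound 2 to compound 1, but not the same: in compound 2 the place is ortho to a hydroxy group, meta to a large group and meta to a methyl group, whereas in compound 3 it is meta to a large group and para to a methyl group.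

With compound 3 at the limit of > 14000 nM in this assay, at which 1 of the 3 values shown sits, and the earlier pair at the limit of > 25000 nM in this assay, at which 2 of the 3 values shown sit, the expected step that the limit leaves unreadable from compound 3 to compound 4 in this assay is essentially flat. Compound 4 is estimated at 30000 nM, between 14000 nM and 100000 nM, and most likely reported only as a limit.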

Compound 4, half-maximal effective concentration: > 14000 nM
Compound 4 gave a limit, no number; the forecaster's own chance of this, stated with the estimate: 85%; the middle value is on the limit's open side.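

In this assay compound 4 gives > 14000 nM, which is a limit of the assay and not a number. Compound 3 sits at the same limit, so no step can be read from compound 3 to compound 4: the limit of > 14000 nM in this assay, at which 2 of the 4 values shown sit.

The compounds shown leave open how large the exchange of 1,3-benzothiazol-2-yl for 1,3-benzoxazol-2-yl really is, and at what concentration any of these compounds would reach the half-maximal effect.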